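The source may hold more compounds than are shown below. What is called first, only, known or untested is meant among the compounds shown, and "the series" means these compounds.

Results so far in a functional assay on HepG2 cells (Homo sapiens), read by MTT assay, with a stated time of 48 h (a lower number here means a stronger inhibitor, a higher number a weaker inhibitor), are these
Compound 1 `CCN(CC)CCNC(=O)c1ccc(C(CC)(CC)c2ccc(OCC(O)C(C)(C)C)c(C)c2)n1CC` gives 490 nM
Compound 2 `CCn1c(C(=O)NCCCN(C)C)ccc1C(CC)(CC)c1ccc(OCC(O)C(C)(C)C)c(C)c1` gives 360 nM
Compound 3 `C#CC(C)OC(=O)c1ccc(C(CC)(CC)c2ccc(OCC(O)C(C)(C)C)c(C)c2)n1CC` gives > 50000 nM as a limit

Compound 3 stands at > 50000 nM as a limit of the assay and not as a number. Compound 4 `CCn1c(C(=O)Oc2ccc(CCO)cc2)ccc1C(CC)(CC)c1ccc(OCC(O)C(C)(C)C)c(C)c1` keeps the core of compound 3 and its oxygen next to a carbonyl group, with 4-(2-hydroxyethyl)phenyl in place of 1-methylprop-2-yn-1-yl on that oxygen (4-(2-hydroxyethyl)phenyl in place of 1-methylprop-2-yn-1-yl on an oxygen next to a carbonyl group).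

Among the measured compounds shown here, no measured step changes the group on that oxygen, so the evidence is only indirect. Putting (1-methylprop-2-yn-1-yl)oxy in place of the amino side chain on the carbonyl carbon gave an at least 100-fold higher number from compound 1 to compound 3 (2.00 log units; beyond the scatter) and also an at least 130-fold higher number from compound 2 to compound 3 (2.14 log units; beyond the scatter) as two large steps. Swapping one amino side chain for the other gave only a 1.4-fold lower number from compound 1 to compound 2 (0.13 log units; within the scatter) as a step. Compound 4 has no amino side chain either. Given the loss of that side chain in an at least 130-fold higher number from compound 2 to compound 3 (2.14 log units; beyond the scatter) and its size, compound 4 is expected to keep a number far higher than those of compounds 1 and 2. In this assay only a modest step toward a lower number is therefore expected, and possibly none that can be read. The expected step is an at least 2.0-fold lower number from compound 3 to compound 4 (0.30 log units; that floor lies within the scatter) as estimated here. Compound 4 is estimated at 25000 nM with an expected range from 5000 nM to 50000 nM in all.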

Compound 4, half-maximal inhibitory concentration: > 50000 nM
Compound 4: only a limit was reported (the forecaster's own chance of this, stated with the estimate: 55%); middle value at least 2.0-fold (0.30 log units) away from the limit.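

Compound 4 places a larger group with an aromatic ring and a hydrogen-bond donor, 4-(2-hydroxyethyl)phenyl, on the oxygen next to a carbonyl group, yet in this assay compound 4 gives > 50000 nM, which is a limit of the assay and not a number. Compound 3 also stands at a limit, so the step between these two compounds cannot be read. What can be read is that this second, very different group on that oxygen also leaves a large gap to the compounds with amino side chains, with an at least 130-fold higher number from compound 2 to compound 4 (2.14 log units; beyond the scatter) and an at least 100-fold higher number from compound 1 to compound 4 (2.00 log units; beyond the scatter), so neither group tried on that oxygen gives a value that can be read in this assay: the limit of > 50000 nM in this assay, at which 2 of the 4 values shown sit.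

On these data alone, how far compound 3 and compound 4 lie past the limit stays open, as does whether the change from nitrogen to oxygen on the carbonyl carbon or the loss of the amine in the side chain accounts for the large steps. An ester carrying a dimethylamino chain, set against an amide carrying 4-(2-hydroxyethyl)phenyl, would separate the two.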